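Adding a methyl to compound 3

The compounds below may be only part of what the source reports. "The series", "measured", "known", "first", "only" and "open" are said of these compounds alone.

Measured in a functional assay on PANC-1 cells (Homo sapiens) for cytotoxicity, read by WST assay, with a stated time of 24 h; on this read-out higher numbers stand for weaker inhibition and lower numbers for stronger inhibition:
Compound 1 `O=C(/C=C/CCCCCCc1ccccc1)N1CCCCCC1`: > 100000 nM, a limit
Compound 2 `O=C(/C=C/CCCCCCc1ccccc1)N[C@H]1CC[C@H](O)CC1`: > 100000 nM, a limit
Compound 3 `O=C(CCCCCCCCc1ccccc1)N1CCCCC1`: > 100000 nM, a limit

In this assay compound 3 gives > 100000 nM, which is a limit and not a number. The same holds across the series, with the limit of > 100000 nM in this assay, at which 3 of the 3 values shown sit. Compound 4 `Cc1ccc(CCCCCCCCC(=O)N2CCCCC2)cc1` differs from compound 3 by one change: methyl in place of hydrogen on an aromatic carbon. Within the data shown here, the only measured step, a step that the two limits leave unreadable from compound 1 to compound 2, lies elsewhere in the structure and offers no size to carry over. No step beyond the scatter is therefore expected in this assay, and a further limit is the likeliest report. The expected step is a step that the limit leaves unreadable from compound 3 to compound 4. For compound 4 the estimated value is 150000 nM, with an expected range from 70000 nM to 300000 nM.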

Compound 4, half-maximal inhibitory concentration: > 100000 nM
Compound 4 was reported as a limit; the forecaster's own chance of this, stated with the estimate: 85%; the middle value does not contradict the limit.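

In this assay no step can be read from compound 3 to compound 4, since both values are limits: the limit of > 100000 nM in this assay, at which 4 of the 4 values shown sit.

Whether methyl in place of hydrogen on an aromatic carbon changes the result in this assay stays open, as does where any of these compounds would give a number.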